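Hydroxy in place of hydrogen on compound 3

The source may hold more compounds than are shown below. What is called first, only, known or untested is meant among the compounds shown, and "the series" means these compounds.

In a functional assay on MCF7 cells (Homo sapiens) for antiproliferative activity, read by MTT assay, with a stated time of 72 h (on this read-out lower numbers stand for stronger inhibition and higher numbers for weaker inhibition), compound 1 (`O=C(N/N=C/c1ccc(Br)cc1)Nc1ccc(Oc2ccnc3[nH]ccc23)c(F)c1`) gives 930 nM. In the same read-out compound 2 (`O=C(N/N=C/c1ccc([N+](=O)[O-])cc1)Nc1ccc(Oc2ccnc3[nH]ccc23)c(F)c1`) gives 4000 nM. Compound 3 (`O=C(N/N=C/c1ccc(O)cc1)Nc1ccc(Oc2ccnc3[nH]ccc23)c(F)c1`) is reported as "not active" (no number reported), so it offers no number to start from. Compound 4 (`O=C(N/N=C/c1ccc(O)cc1O)Nc1ccc(Oc2ccnc3[nH]ccc23)c(F)c1`) differs from compound 3 by one change: hydroxy in place of hydrogen on an aromatic carbon. This turns 4-hydroxyphenyl into 2,4-dihydroxyphenyl. Within the data shown here, the only measured step, a 4.3-fold higher number from compound 1 to compound 2 (0.63 log units; beyond the scatter), is modest and beyond the scatter, but it places nitro in place of bromo and adds no hydroxy. It therefore bears only loosely, as a rough size for one substituent exchange in this series. With no number for compound 3, no step size can be stated for this change in this assay. Weak activity is expected, and a report without a number remains quite possible. Any number that appears is expected to fall near that of compound 2 at 4000 nM. For compound 4 the estimated value is 6000 nM, with an expected range of 1500 nM to 25000 nM.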

Compound 4, half-maximal inhibitory concentration: 48000 nM
Beside the measured number, compound 4's estimate is 8.0-fold (0.90 log units) below it, outside the stated range (above it).
By their numbers in this assay, from the lowest: compound 1; then compound 2; then compound 4.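

The 2,4-dihydroxyphenyl group yields a readable number in this assay, where the 4-hydroxyphenyl group alone gave none, but that number is high: a 12-fold higher number from compound 2 to compound 4 (1.08 log units; beyond the scatter) and a 52-fold higher number from compound 1 to compound 4 (1.71 log units; beyond the scatter). A hydroxy on this aromatic carbon, ortho to a large group, thus moves the series from a report without a number to a measurable but weak result; the step itself cannot be read, as compound 3 has no number. Nothing at hand accounts for this result.

From the compounds shown here alone, whether a methoxy group or an amine on the same aromatic carbon would also give a readable number remains open. Also open, going by these compounds, is how a hydroxy at this place would act on the 4-bromophenyl group of compound 1.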